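Replacing a Hydroxyphenyl Group with a Dimethylphenyl Group

The compounds below may be only part of what the source reports. "The series", "measured", "known", "first", "only" and "open" are said of these compounds alone.

In a functional assay on HL-60 cells (Homo sapiens) for cytotoxicity, read by WST assay, with a stated time of 48 h (on this read-out lower numbers stand for an effect already at smaller amounts and higher numbers for an effect only at larger amounts of compound), compound 1 `O=C1OC[C@H](Cc2cccc(O)c2)[C@H]1Cc1ccc(Cl)c(Cl)c1` gives 48000 nM, and compound 2 `O=C1OC[C@H](Cc2ccc(O)cc2)[C@H]1Cc1ccc(Cl)c(Cl)c1` gives 37000 nM. These two numbers lie within the usual scatter of repeated measurements, so compound 2 stands level with compound 1. Compound 3 `Cc1ccc(C[C@H]2COC(=O)[C@@H]2Cc2ccc(Cl)c(Cl)c2)cc1C` differs from compound 2 in one place: 3,4-dimethylphenyl in place of 4-hydroxyphenyl on a saturated chain carbon bound to a saturated ring carbon. In words, 3,4-dimethylphenyl takes the place of 4-hydroxyphenyl on a saturated chain carbon bound to a saturated ring carbon. Among the compounds with values here, only one measured step bears on this change: a 1.3-fold lower number from compound 1 to compound 2 (0.11 log units; within the scatter). Within the data shown here, that step is small, but it only exchanges 3-hydroxyphenyl for 4-hydroxyphenyl, and no measured compound lacks the hydroxy group. The guide is therefore weak, and no step beyond the scatter is expected in this assay. The expected change is a 1.2-fold lower number from compound 2 to compound 3 (0.09 log units; within the scatter). For compound 3 the estimated value is 30000 nM, with an expected range from 10000 nM to 90000 nM.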

Compound 3, half-maximal effective concentration: 16000 nM
Estimate against measurement, compound 3: 1.9-fold (0.27 log units) above, and the stated range covers the measured number.
By their numbers in this assay, from the lowest: compound 3; then compounds 2 and 1 (each within the scatter of the next).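

In this assay, the group on a saturated chain carbon bound to a saturated ring carbon now proves able to shift the number beyond the scatter: 3,4-dimethylphenyl in place of 4-hydroxyphenyl gives a 2.3-fold lower number from compound 2 to compound 3 (0.36 log units; beyond the scatter), and in place of 3-hydroxyphenyl it gives a 3.0-fold lower number from compound 1 to compound 3 (0.48 log units; beyond the scatter). The two hydroxyphenyl compounds stood level, so the earlier pair showed no such shift, and compound 3 shows that a hydroxy group on this ring is not required for the effect seen here. Nothing measured here explains the shift. This one exchange removes the hydroxy group and brings in the two methyl groups together, so the compounds shown cannot separate these two parts of the change. From the compounds shown here alone, how a plain phenyl or an aminophenyl group would read at this place remains open.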